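The source may report more compounds than this note shows. Statements on the series, on what has been measured and on what is new or still open speak of the compounds shown alone.

Of the compounds shown here, three that share one core have been measured in a functional assay on the whole organism (strain Kunming) for inhibition, with Mus musculus as the target, with a stated time of 1 h, at a dose of 40 mg/kg by the oral route; on this read-out lower numbers stand for less inhibition and higher numbers for more inhibition at the one dose given (going by the name of the read-out). Compound 1 `O=C(/C=C/c1ccccc1)c1ccc(N2CCN(c3ccccc3F)CC2)cc1` gives 0.57%. Compound 2 `O=C(/C=C/c1ccccc1)c1ccc(N2CCN(c3ccccc3)CC2)cc1` gives 3.71%. Going by the values given here, the one measured step between them, a number 3.1 percentage points higher from compound 1 to compound 2 (within the scatter), is a change of a fluoro to a hydrogen on an aromatic carbon. Compound 3 `O=C(/C=C/c1ccccc1)c1ccc(N2CCN(S(=O)(=O)c3ccc4ccccc4c3)CC2)cc1` gives 35%, the highest of the three numbers; its gap to compound 2 and its gap to compound 1 both lie beyond the scatter, so compound 3 stands alone at the top of this small set.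

Compound 4 `CCCCc1ccc(S(=O)(=O)N2CCN(c3ccc(C(=O)/C=C/c4ccccc4)cc3)CC2)cc1` has not been measured. It differs from compound 3 in one place: 4-butylphenyl in place of naphthalen-2-yl on a sulfonyl sulfur. Among the compounds with values here, no measured step bears on this change. Within the data shown here, the only step in hand concerns a different part of the molecule and stays within the scatter. Among the measured compounds shown here, compound 3 is the only measured compound carrying a sulfonyl group, and nothing shows how an exchange of the group on that sulfur moves the read-out. The expectation therefore rests on compound 3 alone, and the estimated step, a number 5 percentage points lower from compound 3 to compound 4 (within the scatter), is expected to stay within the scatter. Compound 4 is estimated at 30%, between 10% and 50%.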

Compound 4, a percentage reported as inhibition, in the whole organism at one dose (the size of the read-out at that dose, not a potency): 24%
Estimate against measurement, compound 4: 6 percentage points above; low and high end bracket the measured number.
By their numbers in this assay, from the lowest: compounds 1 and 2 (each within the scatter of the next); then compound 4; then compound 3.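

In this assay, going by these compounds alone, the group on the sulfonyl sulfur proves able to move the read-out: replacing naphthalen-2-yl with 4-butylphenyl gives a number 11 percentage points lower from compound 3 to compound 4 (beyond the scatter) and is the first measured step at this position. Unlike the fluoro-to-hydrogen step on the aromatic carbon, this modest step lies beyond the scatter, although the two groups match in their count of heavy atoms, all carbon, and in having no hydrogen-bond donors or acceptors and no net charge. What the counts do separate is one six-membered aromatic ring in the entering group against two in the leaving one, but no measurement in hand gives a reason for the lower number, and this single step cannot tell the loss of the second ring from the gain of the butyl chain.

An unsubstituted phenyl on the sulfonyl sulfur, a shorter methyl or a longer hexyl chain in place of the butyl, or an amine or a carboxylic acid on that aromatic ring would help to separate these two parts of the change. Also open, from the compounds shown here alone, is how such compounds would behave at other oral doses, or whether a carbonyl could stand in place of the sulfonyl group.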